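Notes on a methoxy-to-hydrogen step in growth inhibition

The source may hold more compounds than are shown below. What is called first, only, known or untested is meant among the compounds shown, and "the series" means these compounds.

Compound 1 `COc1ccc(-c2cc(/C=C/C(=O)c3ccc(N)cc3)[nH]n2)cc1` and compound 2 `COc1ccc(-c2cc(/C=C/C(=O)c3ccc(N)cc3)[nH]n2)cc1OC` share one core; compound 3 `COc1cc(C(=O)/C=C/c2cc(-c3cc(OC)c(OC)c(OC)c3)n[nH]2)cc(OC)c1OC` carries another, and the difference between the two cores is not broken down here. In a functional assay on HOP-62 cells (Homo sapiens) for inhibition, read by sulforhodamine B assay, with a stated time of 48 h (on this read-out higher numbers stand for weaker inhibition of growth and lower numbers for stronger inhibition of growth), compound 1 gives 2800 nM, compound 2 gives 2800 nM, and compound 3 gives 1460 nM. The change hydrogen in place of methoxy on an aromatic carbon produced no change at the digits printed from compound 2 to compound 1 (within the scatter). Compound 4 `COc1ccc(-c2cc(/C=C/C(=O)c3cc(OC)c(OC)c(OC)c3)[nH]n2)cc1OC`, not yet measured, arises from compound 3 through (hydrogen in place of methoxy on an aromatic carbon); this is the same kind of change, the place differing only in being also meta to a methoxy group. Because no change at the digits printed from compound 2 to compound 1 (within the scatter) was within the scatter, compound 4 is expected to give 1600 nM in this assay, with a range of 700 nM to 3600 nM. The expected step of a 1.1-fold higher number from compound 3 to compound 4 (0.04 log units; within the scatter) is estimated to stay within the scatter.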

Compound 4, concentration for 50% growth inhibition: 1450 nM
Compound 4: middle estimate off by 1.1-fold (0.04 log units), on the high side; the range from low to high includes it.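

In this assay, hydrogen in place of methoxy on an aromatic carbon gives a 1.0-fold lower number from compound 3 to compound 4 (0.00 log units; within the scatter), and the step reads the same on both cores: the same change on two cores in this assay, no change at the digits printed (within the scatter) from compound 2 to compound 1 and a 1.0-fold lower number (0.00 log units; within the scatter) from compound 3 to compound 4, 1.0-fold (0.00 log units) apart, within the scatter of two such steps. On these two cores, then, the change carries over without a difference beyond the scatter. This rests on two pairs in a single assay and does not show that the same would hold on other cores, at other places on the ring or in other cell lines.

The compounds shown leave open what a hydroxy group, a chlorine atom or an amine would do in place of the methoxy group. Also open, going by these compounds, is how much the remaining differences between the two cores contribute.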